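Lengthening an Alkoxy Chain on a Bromodimethoxy Cyclohexanone Scaffold

The source may report more compounds than this note shows. Statements on the series, on what has been measured and on what is new or still open speak of the compounds shown alone.

Measured so far:
Compound 1, `COc1cc(/C=C2\CCC/C(=C\c3cccc([N+](=O)[O-])c3)C2=O)cc(Br)c1OC`, in a functional assay on MCF7 cells (Homo sapiens) for cytotoxicity, read by MTT assay (a lower number here means a stronger inhibitor, a higher number a weaker inhibitor), gives 4.72 ug/mL.
Compound 2, `CCOc1c(Br)cc(/C=C2\CCC/C(=C\c3cccc([N+](=O)[O-])c3)C2=O)cc1OC`, in this assay gives 24.9 ug/mL.
Compound 3, `CCCOc1c(Br)cc(/C=C2\CCC/C(=C\c3ccc([N+](=O)[O-])cc3)C2=O)cc1OC`, in this assay gives 7.98 ug/mL.

Compound 1 and compound 2 differ in one place: methyl in place of hydrogen on a saturated chain carbon bound to an oxygen on an aromatic ring. This change gave a 5.3-fold higher number from compound 1 to compound 2 (0.72 log units; beyond the scatter). Compound 3 carries a different core; the difference between the core of compound 3 and that of compound 1 is not broken down here. Compound 3 stands close to compound 1, within the usual scatter, and clearly lower than compound 2.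

Compound 4, `CCCCOc1c(Br)cc(/C=C2\CCC/C(=C\c3ccc([N+](=O)[O-])cc3)C2=O)cc1OC`, has not yet been measured. It differs from compound 3 in one place: methyl in place of hydrogen on a saturated chain carbon, three bonds along the chain from an oxygen on an aromatic ring. Among the measured compounds shown here, this is the same kind of change as the one from compound 1 to compound 2, but the place differs: there the new methyl sat on a saturated chain carbon bound to an oxygen on an aromatic ring, here it sits three bonds along the chain from that oxygen. For the measured compounds named here, a smaller rise than a 5.3-fold higher number from compound 1 to compound 2 (0.72 log units; beyond the scatter) is expected here, namely a 1.6-fold higher number from compound 3 to compound 4 (0.21 log units; within the scatter), resting on the single measured step as the only guide. Compound 4 is therefore estimated to give 13 ug/mL in this assay, with a range from 5 ug/mL to 32 ug/mL.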

Compound 4, half-maximal inhibitory concentration: 27 ug/mL
For compound 4 the middle estimate is 2.1-fold (0.32 log units) below the measured one; the measured number falls inside the stated range.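

Lengthening the alkoxy chain by one carbon made the compound a weaker inhibitor on both cores, and in this assay the new step is a 3.4-fold higher number from compound 3 to compound 4 (0.53 log units; beyond the scatter). Set side by side, the two steps cannot be told apart in size, so in these two pairs the change carried over from one core to the other with much the same result: the same change on two cores in this assay, a 5.3-fold higher number (0.72 log units; beyond the scatter) from compound 1 to compound 2 and a 3.4-fold higher number (0.53 log units; beyond the scatter) from compound 3 to compound 4, 1.6-fold (0.19 log units) apart, within the scatter of two such steps. Among the compounds shown here, this is only two pairs, however, and they differ in more than the core, since one step is methyl to ethyl and the other is propyl to butyl, so the effect of the core cannot be separated from that of the place on the chain, and no general rule for other cores follows.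

The compounds shown leave open whether the number keeps rising with a longer chain, such as pentyl. They also leave open what an amine or a carboxylic acid in place of the nitro group would do in this assay.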